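The compounds below may be only part of what the source reports. "The series", "measured", "known", "first", "only" and "open" are said of these compounds alone.

Among the measured compounds shown here, in a functional assay on T47D cells (Homo sapiens) for cytotoxicity, read by MTT assay (on this read-out higher numbers stand for weaker inhibition and lower numbers for stronger inhibition), compound 2 `O=C(/C=C/c1ccc(N2CCCC2)cc1)c1ccc(O)cc1` gives 1370 nM, the lowest number so far, while compound 1 `COc1ccc(C(=O)/C=C/c2ccc(F)cc2)c(O)c1` gives 21900 nM. Compound 3 `O=C(/C=C/c1ccc(N2CCCC2)cc1)c1ccc(F)cc1` reaches only a limit, > 25000 nM. Compound 4 `O=C(/C=C/c1ccc(N2CCCC2)cc1)c1ccc(O)cc1O` keeps the core of compound 2 and adds one group: hydroxy in place of hydrogen on an aromatic carbon, ortho to a large group and meta to a hydroxy group. For the measured compounds named here, the one measured step that bears on this is large: an at least 18-fold higher number from compound 2 to compound 3 (1.26 log units; beyond the scatter), with fluoro in place of hydroxy on an aromatic carbon. Going by the values given here, compound 4 keeps that existing hydroxy, so no step of that size is expected, and it should stay close to compound 2 at 1370 nM. The expected change is small, a 1.1-fold lower number from compound 2 to compound 4 (0.06 log units; within the scatter), within the scatter. For compound 4 the estimated value is 1200 nM, with an expected range of 350 nM to 4500 nM.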

Compound 4, half-maximal inhibitory concentration: 6990 nM
For compound 4 the middle estimate is 5.8-fold (0.77 log units) below the measured one; the measured number lies above the stated range.
By their numbers in this assay, from the lowest: compound 2; then compound 4; then compound 1. At a limit, above all of these: compound 3.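

In this assay, a new hydroxy on an aromatic carbon, ortho to a large group and meta to a hydroxy group, does not leave the number unchanged: a 5.1-fold higher number from compound 2 to compound 4 (0.71 log units; beyond the scatter). The earlier step changed the existing hydroxy, while this one shows that filling a hydrogen-bearing place on that ring also counts, though the rise is modest. Nothing measured here gives a reason for this rise. As far as these compounds go, whether an amine or a carboxylic acid at this same place would give a lower or a higher number remains open.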